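The source may report more compounds than this note shows. Statements on the series, on what has been measured and on what is new or still open speak of the compounds shown alone.

Of the compounds shown here, three of one series have been tested in a functional assay on B16-F0 cells (Mus musculus) for inhibition, read by CCK-8 assay, with a stated time of 48 h; on this read-out higher numbers stand for weaker inhibition and lower numbers for stronger inhibition. Compound 1 `COc1cc(-c2cc3nccc(-c4c[nH]c5ccccc45)n3n2)cc(OC)c1OC` gives > 10000 nM in this assay, a limit of the measurement rather than a number. Compound 2 `COc1cc(-c2ccnc3cc(-c4ccccc4)nn23)cc(OC)c1OC` gives 4730 nM in this assay, and compound 3 `COc1cc(-c2ccnc3cc(-c4cn(C(=O)OC(C)(C)C)c5ccccc45)nn23)cc(OC)c1OC` gives 3070 nM. Of the two numbers shown, that of compound 2 is the larger, yet the gap to compound 3 lies within the usual scatter, so the two compounds cannot be told apart on these data.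

Compound 4 `COc1ccc(-c2cc3nccc(-c4cc(OC)c(OC)c(OC)c4)n3n2)cc1` has not yet been measured. It differs from compound 2 in one place: methoxy in place of hydrogen on an aromatic carbon. For the measured compounds named here, no pair of measured compounds shares this change, so there is no measured step to lean on. The account therefore expects only a small step in this assay, with no movement beyond the scatter in either direction, and the estimated step is a 1.4-fold lower number from compound 2 to compound 4 (0.13 log units; within the scatter). Compound 4 is accordingly estimated at 3500 nM in this assay, with a range from 1200 nM to 10000 nM.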

Compound 4, half-maximal inhibitory concentration: 1410 nM
Estimate against measurement, compound 4: 2.5-fold (0.39 log units) above; the measured number falls inside the stated range.
By their numbers in this assay, from the lowest: compound 4; then compounds 3 and 2 (each within the scatter of the next). At a limit, above all of these: compound 1.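

In this assay, for the compounds shown here, the change from phenyl to 4-methoxyphenyl gives a 3.4-fold lower number from compound 2 to compound 4 (0.53 log units; beyond the scatter), and this is the first step that can be read across a single place. Going by these compounds alone, it shows that the aromatic carbon para to a large group is a place where methoxy in place of hydrogen moves the number beyond the scatter, which the earlier compounds, none of them differing from one another in one place, could not show. Nothing in the data at hand accounts for the size of this step.

The compounds shown leave open whether the step belongs to methoxy in particular or would also come with a hydroxyl, an amine or a longer chain such as ethoxy at the same place. They also leave open whether a second methoxy on this ring would move the number further.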